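The source may hold more compounds than are shown below. What is called first, only, known or untested is meant among the compounds shown, and "the series" means these compounds.

Working notes on the series.

Compound 3 `Cc1ccc(-c2nnc(-c3c[nH]c4ncc(-c5ccc(S(C)(=O)=O)cc5)cc4c3=O)o2)cc1` gives 11.2% in a functional assay on A549 cells (Homo sapiens) for inhibition, read by MTT assay, with a stated time of 24 h, tested at 10 uM; a higher number here means more inhibition of growth at the concentration tested, a lower number less inhibition of growth. Among the three measured compounds it stands second highest; compound 1 `CS(=O)(=O)c1ccc(-c2cnc3[nH]cc(-c4nnc(-c5ccccc5)o4)c(=O)c3c2)cc1` gives 9.51%, and the pair lies within the scatter. Compound 2 `CS(=O)(=O)c1ccc(-c2cnc3[nH]cc(-c4nnc(-c5ccc(Cl)cc5)o4)c(=O)c3c2)cc1` gives 26.8%, and the step of a number 15.6 percentage points lower from compound 2 to compound 3 (beyond the scatter) is beyond the scatter. The step of a number 1.7 percentage points higher from compound 1 to compound 3 (within the scatter) is within the scatter, while the step of a number 17.3 percentage points higher from compound 1 to compound 2 (beyond the scatter) is beyond it.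

Compound 4 `Cc1cccc(-c2nnc(-c3c[nH]c4ncc(-c5ccc(S(C)(=O)=O)cc5)cc4c3=O)o2)c1` has not yet been measured. It differs from compound 3 in one place: 3-methylphenyl in place of 4-methylphenyl on an aromatic carbon. Among the measured compounds shown here, no measured step moves a methyl from one aromatic carbon to another; the measured steps only swap hydrogen, chloro and methyl at a single carbon. Of these, the methyl-bearing compound 3 sits within the scatter of the unsubstituted compound 1, so the methyl itself has shown no effect beyond the scatter so far.

The expectation is therefore a step of a number 0.8 percentage points higher from compound 3 to compound 4 (within the scatter), not beyond the scatter. Compound 4 is estimated at 12%, with a range from 3% to 26%.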

Compound 4, percent growth inhibition at one concentration: 8.95%
Estimate against measurement, compound 4: 3.1 percentage points above; the range from low to high includes it.
By their numbers in this assay, from the lowest: compounds 4, 1 and 3 (each within the scatter of the next); then compound 2.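

In this assay, 3-methylphenyl in place of 4-methylphenyl gives a step of a number 2.3 percentage points lower from compound 3 to compound 4 (within the scatter) and so shows that, for a methyl on this aromatic ring, where it stands makes no difference that can be read here. Set against the unsubstituted ring, the same methyl gives a number 0.6 percentage points lower from compound 1 to compound 4 (within the scatter) as its step, which extends the earlier reading to a second methyl placement, and against the 4-chlorophenyl it gives a number 17.9 percentage points lower from compound 2 to compound 4 (beyond the scatter) as its step, so compound 2 remains separate from both methyl compounds. No measurement available here explains the separation of compound 2 from the others.

Open, on these data alone, is whether a chloro placed as the methyl stands in compound 4 would keep the reading of compound 2. Also open, as far as these compounds go, is how an amine, a methoxy group or a carboxylic acid on this aromatic ring would read in this assay at all.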